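Furan-2-yl for thiophen-3-yl on a nucleoside core

The source may hold more compounds than are shown below. What is called first, only, known or untested is meant among the compounds shown, and "the series" means these compounds.

For the measured compounds named here, compound 1 `COc1ncnc2c1c(-c1ccsc1)cn2[C@@H]1O[C@H](CO)[C@@H](O)[C@H]1O` is the only member of the set with a numerical reading: in a functional assay on K562 cells (Homo sapiens), read by MTT assay, with a stated time of 72 h (on this read-out higher numbers stand for weaker inhibition and lower numbers for stronger inhibition), compound 1 gives 3450 nM. Compound 2 `CNc1ncnc2c1c(-c1ccsc1)cn2[C@@H]1O[C@H](CO)[C@@H](O)[C@H]1O` reaches only a limit of the assay in this assay, > 20000 nM. Compound 3 `CSc1ncnc2c1c(-c1ccsc1)cn2[C@@H]1O[C@H](CO)[C@@H](O)[C@H]1O` likewise reaches only a limit, > 20000 nM. Hence an at least 5.7-fold higher number from compound 1 to compound 2 (0.76 log units; beyond the scatter) and an at least 5.7-fold higher number from compound 1 to compound 3 (0.76 log units; beyond the scatter), both beyond the scatter, while a step that the two limits leave unreadable from compound 2 to compound 3. Compound 4 `COc1ncnc2c1c(-c1ccco1)cn2[C@@H]1O[C@H](CO)[C@@H](O)[C@H]1O` differs from compound 1 in another place: furan-2-yl in place of thiophen-3-yl on an aromatic carbon. Going by the values given here, none of the measured steps touches this position, so they give no direct guide to its size or direction. Compound 4 is therefore expected to change little, with a 1.4-fold higher number from compound 1 to compound 4 (0.16 log units; within the scatter), estimated at 5000 nM (range 1500 nM to 20000 nM).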

Compound 4, half-maximal inhibitory concentration: 380 nM
Estimate against measurement, compound 4: 13-fold (1.12 log units) above; the measured number lies below the stated range.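

In this assay, the group on this aromatic carbon proves to matter: furan-2-yl in place of thiophen-3-yl gives a 9.1-fold lower number from compound 1 to compound 4 (0.96 log units; beyond the scatter) and is the first change shown that strengthens inhibition. The two rings match in heavy atoms and hydrogen-bond acceptors, differing only in sulfur against oxygen and in the ring carbon that carries the core. Nothing given here accounts for the change. Thiophen-2-yl and furan-3-yl would separate the hetero atom from the attachment point, and that question stays open. On these data alone, whether furan-2-yl would act alike with methylamino or methylsulfanyl in place of methoxy also stays open.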